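This account rests on a few compounds, and the source may have more. Where it says the series, first, only, none or still open, it means among the compounds named here.

Measured in a functional assay on LNCaP cells (Homo sapiens) for cytotoxicity, read by MTT assay, with a stated time of 72 h; a higher number here means a weaker inhibitor, a lower number a stronger inhibitor:
- Compound 1 `COc1cc(/C=C/C(O)=C/C(=O)/C=C/C2=C(C)CCCC2(C)C)ccc1O`: 20600 nM
- Compound 2 `COc1ccc(/C=C/C(O)=C/C(=O)/C=C/C2=C(C)CCCC2(C)C)cn1`: 25100 nM

Within the data shown here, these two values lie within the usual scatter of each other, so compound 2 stands level with compound 1 on the numbers so far. Compound 3 `COc1ccc(/C=C/C(O)=C/C(=O)/C=C/C2=C(C)CCCC2(C)C)cc1O` differs from compound 2 by one change: 3-hydroxy-4-methoxyphenyl in place of 6-methoxypyridin-3-yl on a double-bonded chain carbon bound to a double-bonded chain carbon. This puts 3-hydroxy-4-methoxyphenyl in place of 6-methoxypyridin-3-yl on a double-bonded chain carbon bound to a double-bonded chain carbon.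

Among the measured compounds shown here, only one measured step bears on this change, a 1.2-fold higher number from compound 1 to compound 2 (0.09 log units; within the scatter), which exchanged 4-hydroxy-3-methoxyphenyl for that same 6-methoxypyridin-3-yl and stayed within the scatter. The step expected in this assay is therefore small, estimated as a 1.3-fold lower number from compound 2 to compound 3 (0.10 log units; within the scatter), with no real shift in either direction. For compound 3 the expected value is 20000 nM, with an estimated range from 10000 nM to 40000 nM.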

Compound 3, half-maximal inhibitory concentration: 25900 nM
The estimate for compound 3 lay 1.3-fold (0.11 log units) below the measured number, within the range that was stated.
By their numbers in this assay, from the lowest: compounds 1, 2 and 3 (each within the scatter of the next).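

In this assay, 3-hydroxy-4-methoxyphenyl in place of 6-methoxypyridin-3-yl gives a 1.0-fold higher number from compound 2 to compound 3 (0.01 log units; within the scatter), and the same group in place of 4-hydroxy-3-methoxyphenyl gives a 1.3-fold higher number from compound 1 to compound 3 (0.10 log units; within the scatter). On a double-bonded chain carbon bound to a double-bonded chain carbon, these three groups therefore stand level, and this now holds for two phenyl groups that carry the same substituents under different names, as well as for a group with no hydrogen-bond donor and groups with one. No measurement at hand accounts for this level reading.

All three groups carry a methoxy on a six-membered aromatic ring, so the compounds shown leave open whether an amine or a carboxylic acid on that ring would shift the number. They also leave open whether a longer chain in place of the methoxy would do so.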